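The compounds below may be only part of what the source reports. "The series", "measured", "known", "first", "only" and "open" are said of these compounds alone.

Measured so far:
Compound 1 `O=C(Oc1ccc([N+](=O)[O-])cc1)N1CCN(S(=O)(=O)c2ccc(-c3ccccc3)cc2)CC1`: 437 nM
Compound 2 `O=C(Oc1ccc([N+](=O)[O-])cc1)N1CCN(S(=O)(=O)c2ccc(Oc3cccc(Cl)c3)cc2)CC1`: 380 nM

In an assay on isolated protein for inhibition of Fatty-acid amide hydrolase 1 (Homo sapiens), read by fluorescence (a higher number here means a weaker inhibitor, a lower number a stronger inhibitor), compound 1 gives 437 nM, and compound 2 gives 380 nM. These two numbers cannot be told apart: a 1.2-fold lower number from compound 1 to compound 2 (0.06 log units; within the scatter). So on the numbers shown, compound 1 stands level with compound 2, neither ahead nor behind it.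

Compound 3 `O=C(Oc1ccc([N+](=O)[O-])cc1)N1CCN(S(=O)(=O)c2ccc(Oc3ccc(Cl)cc3)cc2)CC1` has not yet been measured in this assay. It differs from compound 1 by 4-chlorophenoxy in place of phenyl on an aromatic carbon. Going by the values given here, the only measured step that bears on this change is the one from compound 1 to compound 2, where a 3-chlorophenoxy took the place of the same phenyl and the number barely moved, a 1.2-fold lower number from compound 1 to compound 2 (0.06 log units; within the scatter). Among the compounds with values here, since moving the chlorine within the new ring is the only difference between compound 2 and compound 3, no step beyond the scatter is expected here either: compound 3 is estimated to sit near compound 1, with a 1.1-fold lower number from compound 1 to compound 3 (0.04 log units; within the scatter). The estimate for compound 3 in this assay is 400 nM, expected to fall between 200 nM and 800 nM.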

Compound 3, half-maximal inhibitory concentration: 153 nM
For compound 3 the middle estimate is 2.6-fold (0.42 log units) above the measured one; the whole stated range lies above it.
By their numbers in this assay, from the lowest: compound 3; then compounds 2 and 1 (each within the scatter of the next).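

In this assay the position of the chlorine on the outer ring turns out to matter: with 4-chlorophenyl in place of 3-chlorophenyl on the oxygen, there is a 2.5-fold lower number from compound 2 to compound 3 (0.40 log units; beyond the scatter). Replacing the phenyl with 4-chlorophenoxy also gives a real change, a 2.9-fold lower number from compound 1 to compound 3 (0.46 log units; beyond the scatter), whereas the 3-chlorophenoxy of compound 2 stayed within the scatter of compound 1. Nothing available explains why this shift of one chlorine changes the number.

The compounds shown leave open whether a fluorine, a methyl or a methoxy in place of that chlorine would give a similar step. They also cannot separate the roles of the oxygen and the chlorine, which a 4-chlorophenyl attached directly to the ring, without the oxygen, could do.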